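The source may hold more compounds than are shown below. What is called first, only, known or untested is meant among the compounds shown, and "the series" means these compounds.

Compound 1 `CCCn1cc(S(=O)(=O)c2ccc(CNC(=O)N3Cc4ccncc4C3)cc2)cn1` is the reference point of this series. Going by the values given here, in a functional assay on A2780 cells (Homo sapiens) for cytotoxicity, read by sulforhodamine B assay, with a stated time of 72 h (a lower number here means a stronger inhibitor, a higher number a weaker inhibitor), compound 1 gives 7.3 nM, the lowest of the three numbers measured so far. Compound 2 `O=C(NCc1ccc(S(=O)(=O)C2CCCOC2)cc1)N1Cc2ccncc2C1` gives 32 nM in this assay, and compound 3 `CN1CCC(S(=O)(=O)c2ccc(CNC(=O)N3Cc4ccncc4C3)cc2)CC1` gives 99 nM. Both known steps away from compound 1 go the same way: a 4.4-fold higher number from compound 1 to compound 2 (0.64 log units; beyond the scatter), and a 14-fold higher number from compound 1 to compound 3 (1.13 log units; beyond the scatter); the step between those two, a 3.1-fold higher number from compound 2 to compound 3 (0.49 log units; beyond the scatter), places compound 3 furthest from compound 1.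

Compound 4 `O=C(NCc1ccc(S(=O)(=O)N2CCC(N3CCCC3)CC2)cc1)N1Cc2ccncc2C1` differs from compound 1 at the same position as these two: 4-(pyrrolidin-1-yl)piperidin-1-yl in place of 1-propyl-1H-pyrazol-4-yl on a sulfonyl sulfur. Among the compounds with values here, of the measured steps, the one to compound 3 bears most directly on it, since 1-methylpiperidin-4-yl and 4-(pyrrolidin-1-yl)piperidin-1-yl are both built from six-membered non-aromatic rings with one hetero atom and both carry a second nitrogen, whereas the step to compound 2 shows that even oxan-3-yl costs potency. Every replacement of 1-propyl-1H-pyrazol-4-yl seen here raised the number, so a higher number is expected for compound 4 as well, a step of about the size seen for compound 3. The estimate for compound 4 in this assay is therefore 80 nM, with a range from 20 nM to 320 nM, corresponding to an expected 11-fold higher number from compound 1 to compound 4 (1.04 log units; beyond the scatter).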

Compound 4, half-maximal inhibitory concentration: 5.6 nM
Compound 4: middle estimate off by 14-fold (1.15 log units), on the high side, outside the stated range (below it).
By their numbers in this assay, from the lowest: compounds 4 and 1 (each within the scatter of the next); then compound 2; then compound 3.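

With 4-(pyrrolidin-1-yl)piperidin-1-yl on the sulfonyl sulfur, this assay gives a 1.3-fold lower number from compound 1 to compound 4 (0.12 log units; within the scatter), so this position does not depend on keeping 1-propyl-1H-pyrazol-4-yl, and replacing that aromatic group need not cost potency. Non-aromatic groups here also do not behave alike: the same group gives an 18-fold lower number from compound 3 to compound 4 (1.25 log units; beyond the scatter) and a 5.7-fold lower number from compound 2 to compound 4 (0.76 log units; beyond the scatter), so the earlier rises cannot be read as a general penalty for leaving the pyrazole. Compound 4 is also the only one of the four whose group is joined to the sulfonyl sulfur through a ring nitrogen, and the only one with a second non-aromatic ring, and a single compound cannot separate these two features.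

Nothing in the data explains why these groups differ so widely at this position. From the compounds shown here alone, it remains open whether the pyrrolidine ring or the link through nitrogen matters more, a question that 4-(dimethylamino)piperidin-1-yl or plain morpholin-4-yl on the same sulfonyl sulfur would help to settle.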